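The source may report more compounds than this note shows. Statements on the series, on what has been measured and on what is new or still open speak of the compounds shown alone.

Measured compounds:
- compound 1 `O=C(O)CCCSCCN1C(=O)CC[C@@H]1/C=C/[C@@H](O)Cc1cccc(-c2cc3ccccc3o2)c1`, 0.1 nM
- compound 2 `O=C(O)CCCSCCN1C(=O)CC[C@@H]1/C=C/[C@@H](O)Cc1cccc(OCc2ccncc2)c1`, 28 nM
- compound 3 `O=C(O)c1csc(SCCN2C(=O)CC[C@@H]2/C=C/[C@@H](O)Cc2cccc(-c3ccc(Cl)cc3)c2)n1`, 0.81 nM

These three compounds were tested in an assay on CHO cells for displacement of a labelled ligand from prostaglandin E2 receptor EP4 subtype (Mus musculus), read by scintillation counting, with a stated time of 60 min; a lower number here means a stronger inhibitor, a higher number a weaker inhibitor. Compound 3 gives 0.81 nM, which places it second highest of the three numbers: compound 1 gives 0.1 nM, a clearly lower number, while compound 2 gives 28 nM, a clearly higher one, and both gaps lie beyond the scatter.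

The new compound 4 `Cc1cc(C)c2oc(-c3cccc(C[C@H](O)/C=C/[C@H]4CCC(=O)N4CCSc4nc(C(=O)O)cs4)c3)nc2c1` has not yet been measured. It differs from compound 3 in one place: 5,7-dimethyl-1,3-benzoxazol-2-yl in place of 4-chlorophenyl on an aromatic carbon.

Going by the values given here, only one measured step bears on this. Between compound 1 and compound 2 the group on the same aromatic carbon was changed, and a 280-fold higher number from compound 1 to compound 2 (2.45 log units; beyond the scatter). There the 1-benzofuran-2-yl of compound 1 went with the lowest number seen. The group entering compound 4 is closer in kind to that 1-benzofuran-2-yl than to the 4-chlorophenyl it replaces, so in this assay a lower number than for compound 3 is expected, beyond the scatter but not as far as compound 1 reaches.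

Compound 4 is therefore estimated at 0.3 nM, within a range of 0.08 nM to 1.5 nM, meaning an expected step of a 2.7-fold lower number from compound 3 to compound 4 (0.43 log units; beyond the scatter).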

Compound 4, inhibition constant: 0.15 nM
Beside the measured number, compound 4's estimate is 2.0-fold (0.30 log units) above it; the measured number falls inside the stated range.
By their numbers in this assay, from the lowest: compounds 1 and 4 (each within the scatter of the next); then compound 3; then compound 2.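

In this assay, replacing 4-chlorophenyl with 5,7-dimethyl-1,3-benzoxazol-2-yl gives a 5.4-fold lower number from compound 3 to compound 4 (0.73 log units; beyond the scatter) and counts as a modest step. Going by these compounds alone, the only earlier step at this aromatic carbon lay on the core of compound 1, so this result adds that the group there also moves the number on the different core of compound 3, and that a larger group with two aromatic rings and two hydrogen-bond acceptors can replace a single chlorinated ring without raising the number. Nothing measured here explains why the number falls.

The change alters several things at once, so the compounds shown cannot separate the part played by the two methyl groups from that of the ring nitrogen and oxygen, or from the second ring itself. A 1,3-benzoxazol-2-yl without the methyl groups, a plain phenyl, and a 1-benzofuran-2-yl on the core of compound 3 would each help to pull these parts apart.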